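The compounds below may be only part of what the source reports. "The series", "measured", "known", "first", "only" and "open" are said of these compounds alone.

Compound 1 `COc1cc(N)c(Cl)cc1NC(=O)C1CCN(CC2CCCC2)CC1` gives > 10 mg/kg in a functional assay on the whole organism for antagonist activity, with Mus musculus as the target; a lower number here means that less compound is needed, a higher number that more compound is needed for the effect.
Compound 2 `COc1cc(N)c(Cl)cc1NC(=O)C1CCN(Cc2ccc(OCc3ccccc3)cc2)CC1` gives > 4 mg/kg in this assay.

Both of these numbers are limits of the assay, not measured values. For compound 1, the limit of > 10 mg/kg in this assay, at which 1 of the 2 values shown sits, is all that is known, so its standing in this assay cannot be placed more closely than that. For compound 2, likewise, only the limit of > 4 mg/kg in this assay, at which 1 of the 2 values shown sits, is known. Within the data shown here, the two measured compounds differ in more than one place, so no single step between them can be read.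

Compound 3 `CCCCCN1CCC(C(=O)Nc2cc(Cl)c(N)cc2OC)CC1` differs from compound 1 by butyl in place of cyclopentyl on a saturated chain carbon bound to an amine nitrogen in a ring. Among the measured compounds shown here, with no measured step to rest on, the change from compound 1 is expected to be a number no higher from compound 1 to compound 3 (the limit leaves the size open), that is, nothing beyond the usual scatter in either direction. Compound 3 is therefore expected to give about 10 mg/kg in this assay, within a range of 3 mg/kg to 30 mg/kg, and quite possibly again only a limit.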

Compound 3, dose for half-maximal effect: > 10 mg/kg
Compound 3: no number, only a limit; the forecaster's own chance of this, stated with the estimate: 70%; the middle value lies on the limit itself.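

In this assay compound 3 gives only a limit, > 10 mg/kg. With compound 1 also resting on a limit, no step can be read between compound 1 and compound 3. The compounds shown leave open what dose any of them needs in this assay, and whether exchanging cyclopentyl for butyl changes it.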